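A few compounds are considered here, and "the series" means these few. Any claim that something is new, unique, unknown or untested is made for them only; others in the source may bear on it.

Compounds measured in an assay on DDT1 cells (Cricetulus griseus) for binding affinity to adenosine receptor A1 (Homo sapiens), read by radioligand binding; a lower number here means a stronger inhibitor, a higher number a weaker inhibitor:
Compound 1, `CC(C)/N=C(\S)OC[C@H]1OC(n2cnc3c(NC4CCOC4)ncnc32)[C@H](O)[C@@H]1O`: 36 nM
Compound 2, `O=C(NC1CC1)OC[C@H]1OC(n2cnc3c(NC4CCOC4)ncnc32)[C@H](O)[C@@H]1O`: 209 nM
Compound 3, `O[C@@H]1[C@@H](CO/C(S)=N/C2CC2)OC(n2cnc3c(NC4CCOC4)ncnc32)[C@@H]1O`: 157 nM

Compound 3 stands second highest of the three numbers in this assay. Its nearest neighbour is compound 2, whose number is within the scatter of it, as a 1.3-fold lower number from compound 2 to compound 3 (0.12 log units; within the scatter) shows; its furthest is compound 1, from which a 4.4-fold higher number from compound 1 to compound 3 (0.64 log units; beyond the scatter) separates it beyond the scatter.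

Compound 4, `C=CC/N=C(\S)OC[C@H]1OC(n2cnc3c(NC4CCOC4)ncnc32)[C@H](O)[C@@H]1O`, has not yet been measured. It differs from compound 3 in one place: allyl in place of cyclopropyl on a double-bonded nitrogen. The step that bears on this change is the one at the same double-bonded nitrogen, a 4.4-fold higher number from compound 1 to compound 3 (0.64 log units; beyond the scatter), where a chain without a ring gave the lower number and the cyclopropyl the higher. The other step, a 5.8-fold higher number from compound 1 to compound 2 (0.76 log units; beyond the scatter), concerns a different part of the molecule. Since the allyl, like the isopropyl of compound 1, carries no ring, compound 4 is expected to give a somewhat lower number than compound 3, with a 2.0-fold lower number from compound 3 to compound 4 (0.29 log units; within the scatter) as the estimated step. Compound 4 is therefore estimated at 80 nM in this assay, within a range of 30 nM to 250 nM.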

Compound 4, inhibition constant: 35 nM
For compound 4 the middle estimate is 2.3-fold (0.36 log units) above the measured one, and the stated range covers the measured number.
By their numbers in this assay, from the lowest: compounds 4 and 1 (each within the scatter of the next); then compounds 3 and 2 (each within the scatter of the next).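

In this assay, allyl in place of cyclopropyl on the double-bonded nitrogen gives a 4.5-fold lower number from compound 3 to compound 4 (0.65 log units; beyond the scatter), while allyl in place of isopropyl gives a 1.0-fold lower number from compound 1 to compound 4 (0.01 log units; within the scatter), so the two groups without a ring cannot be told apart here and only the cyclopropyl stands off from them. The larger change gives a 6.0-fold lower number from compound 2 to compound 4 (0.78 log units; beyond the scatter), a step beyond the scatter, whereas the exchange of oxygen for sulfur with cyclopropyl kept gave only a 1.3-fold lower number from compound 2 to compound 3 (0.12 log units; within the scatter), so among these compounds the ring-free group goes with the lower number. No supporting data are available to explain this difference.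

The compounds shown leave open whether a propyl chain, a longer chain or a benzyl group on this nitrogen would keep the number of compound 4. They also leave open whether allyl or isopropyl would give similar numbers with oxygen in place of sulfur.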